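This account rests on a few compounds, and the source may have more. Where it says the series, first, only, none or still open, it means among the compounds named here.

Measured so far:

Compound 1, `O=C(CCCCC1CCSS1)Nc1ccc(Cl)cn1`, gives 6.26% in a functional assay on NCI-H460 cells (Homo sapiens) for inhibition, read by MTT assay, with a stated time of 24 h, tested at 1 ug/mL; a higher number here means more inhibition of growth at the concentration tested, a lower number less inhibition of growth.
Compound 2, `O=C(CCCCC1CCSS1)Nc1ccc(Br)cn1`, gives 13.1% in this assay.
Compound 3, `O=C(CCCCC(S)CCS)Nc1ccc(Cl)cn1`, is reported in this assay only as "not active" (no number reported), with no number given.

Compounds 1 and 2 share one core and differ in a single spot: bromo in place of chloro on an aromatic carbon. The step this makes is a number 6.8 percentage points higher from compound 1 to compound 2 (within the scatter), so the two values cannot be told apart with confidence.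

Compound 3 has a different core. The difference between the two cores is a group of 5 heavy atoms (3 carbon, 2 sulfur; no ring) in place of a group of 5 heavy atoms (3 carbon, 2 sulfur; one five-membered non-aromatic ring with 2 hetero atoms), on a saturated chain carbon, four bonds along the chain from a carbonyl carbon. On this second core, compound 4, `O=C(CCCCC(S)CCS)Nc1ccc(Br)cn1`, is not yet measured. It stands to compound 3 exactly as compound 2 stands to compound 1: bromo in place of chloro on an aromatic carbon. Both "place" descriptions read the same, word for word, so this is the same change made on two cores.

Going by the values given here, the only guide to its size is the step from compound 1 to compound 2, which stayed within the usual scatter. For compound 3 no number exists, only the word that it showed no activity, so the step from compound 3 to compound 4 in this assay cannot be placed against a starting number; the expectation is that it is likewise small, and that compound 4 stays near the low end of the scale, if a number is reported at all.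

For compound 4 in this assay the expected value is 5%, with a likely range from 0% to 15%.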

Compound 4, percent growth inhibition at one concentration: 10.7%
Compound 4: middle estimate off by 5.7 percentage points, on the low side; low and high end bracket the measured number.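

In this assay the new result is a number 2.4 percentage points lower from compound 2 to compound 4 (within the scatter), so with bromo on the aromatic ring, the open chain and the five-membered ring cannot be told apart at this concentration. Going by these compounds alone, this shows only that opening the ring leaves no measurable difference between these two bromo compounds; it does not show that bromo in place of chloro has the same effect on both cores. That change gave a number 6.8 percentage points higher from compound 1 to compound 2 (within the scatter) on the core of compound 1, but the matching step to compound 4 cannot be read, as compound 3 has a word and no number, and no data at hand explain any of these results.

The compounds shown carry only chloro or bromo on that aromatic carbon, so what a methyl, methoxy or nitrile group would give there remains open, as does the effect of a longer chain between the carbonyl and the sulfur atoms. As far as these compounds go, each result also comes from one concentration in one cell line, so it remains open whether these compounds would separate at higher concentrations or in other cells.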